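Chlorothiophene replaces ethoxypyridine on the pyrazole core

A few compounds are considered here, and "the series" means these few. Any claim that something is new, unique, unknown or untested is made for them only; others in the source may bear on it.

Measured so far:
Compound 1, `COc1ccccc1-n1nc(C2CC(C)(C)OC(C)(C)C2)cc1-c1ccc(Cl)cc1`: 1 nM
Compound 2, `CCOc1ccc(-c2cc(C3CC(C)(C)OC(C)(C)C3)nn2-c2ccccc2OC)cn1`: 5 nM

Among the measured compounds shown here, in an assay on HEK293 cells for inhibition of Voltage-dependent N-type calcium channel subunit alpha-1B (Homo sapiens), read by fluorescence and calcium flux, with a stated time of 5 min (on this read-out higher numbers stand for weaker inhibition and lower numbers for stronger inhibition), compound 2 stands at the higher of the two numbers, with compound 1 as its only neighbour, and the step of a 5.0-fold higher number from compound 1 to compound 2 (0.70 log units; beyond the scatter) separates them. Compound 3, `COc1ccccc1-n1nc(C2CC(C)(C)OC(C)(C)C2)cc1-c1csc(Cl)c1`, has not been measured. Its change from compound 2 is 5-chlorothiophen-3-yl in place of 6-ethoxypyridin-3-yl on an aromatic carbon. For the measured compounds named here, the one step that bears on this place is the one from compound 1 to compound 2, where a chlorine-bearing six-membered ring gave way to an ethoxypyridine and the number rose modestly. Going by the values given here, compound 3 again carries a chlorine on the ring at this place, so a return toward the number of compound 1 is expected, though the five-membered ring is new and no step shows its effect. The expected step is a 3.3-fold lower number from compound 2 to compound 3 (0.52 log units; beyond the scatter), a lower number. Compound 3 is estimated at 1.5 nM, within 0.5 nM to 6 nM.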

Compound 3, half-maximal inhibitory concentration: 6 nM
Beside the measured number, compound 3's estimate is 4.0-fold (0.60 log units) below it; the measured number falls inside the stated range.
By their numbers in this assay, from the lowest: compound 1; then compounds 2 and 3 (each within the scatter of the next).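

In this assay, the step from the 6-ethoxypyridin-3-yl group to the 5-chlorothiophen-3-yl group lies within the scatter (a 1.2-fold higher number from compound 2 to compound 3 (0.08 log units; within the scatter)), although the two groups differ in ring size and hetero atom. A chlorine-bearing ring at this place is thus not enough to match compound 1, since the step between the two chlorine-bearing groups lies beyond the scatter (a 6.0-fold higher number from compound 1 to compound 3 (0.78 log units; beyond the scatter)), leaving the 4-chlorophenyl group of compound 1 with the lowest number of the three. No measurement shown accounts for this result.

The compounds shown leave open whether the chlorine or the six-membered ring of the 4-chlorophenyl group matters more, which a plain phenyl ring or a chlorothiophene with the chlorine elsewhere could help to separate. They also leave open how a bromine in place of that chlorine, or an amine on the ring, would read at this place.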